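Opening a Small Ring on the Triazole Substituent

The source may hold more compounds than are shown below. What is called first, only, known or untested is meant among the compounds shown, and "the series" means these compounds.

Measured compounds:
compound 1 `COc1nc2ccc(Br)cc2cc1C(c1ccccc1)n1cc(C2CC2)nn1`, 21.8%
compound 2 `COc1nc2ccc(Br)cc2cc1C(c1ccccc1)n1cc(CCCO)nn1`, 25.5%
compound 3 `COc1nc2ccc(Br)cc2cc1C(c1ccccc1)n1cc(-c2ccc(F)cc2)nn1`, 14.9%

In an ADME assay on PANC-1 cells (Homo sapiens) for cytotoxicity, read by sulforhodamine B assay, with a stated time of 48 h, tested at 10 uM (a lower number here means less inhibition, a higher number more inhibition at the concentration tested (going by the name of the read-out)), compound 1 gives 21.8%, the second highest of the three numbers; its nearest neighbour is compound 2, with a number 3.7 percentage points higher from compound 1 to compound 2 (within the scatter), and the furthest is compound 3, with a number 6.9 percentage points lower from compound 1 to compound 3 (within the scatter). Compound 4 `CCCc1cn(C(c2ccccc2)c2cc3cc(Br)ccc3nc2OC)nn1` has not yet been tested. It differs from compound 1 as follows: propyl in place of cyclopropyl on an aromatic carbon. The step most akin to it is a number 3.7 percentage points higher from compound 1 to compound 2 (within the scatter), where a three-carbon chain also replaces the cyclopropyl and the number stays within the scatter; the aryl replacement in a number 6.9 percentage points lower from compound 1 to compound 3 (within the scatter) is also within the scatter. No step beyond the scatter is therefore expected for compound 4, whose value is estimated at 22% (range 12% to 32%), an expected step of a number 0.2 percentage points higher from compound 1 to compound 4 (within the scatter).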

Compound 4, a percentage reported as inhibition, at one concentration (the size of the read-out at that concentration, not a potency): 11.3%
Estimate against measurement, compound 4: 10.7 percentage points above; measured number outside the range, below it.
By their numbers in this assay, from the lowest: compounds 4, 3, 1 and 2 (each within the scatter of the next, the first and the last beyond it).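

In this assay the ring-opening at this aromatic carbon is not neutral: a number 10.5 percentage points lower from compound 1 to compound 4 (beyond the scatter) shows that cyclopropyl and propyl, with the same count of carbon atoms, need not read alike. The hydroxy also matters on this chain, with a number 14.2 percentage points lower from compound 2 to compound 4 (beyond the scatter) for its loss, while a number 3.6 percentage points lower from compound 3 to compound 4 (within the scatter) leaves propyl and 4-fluorophenyl unseparated. Nothing available here explains these steps. As far as these compounds go, it remains open whether a longer chain such as butyl would follow propyl, and whether an amine in place of the hydroxy would behave like compound 2.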